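Compound 1 to compound 3: removing the methyl

The source may hold more compounds than are shown below. What is called first, only, known or untested is meant among the compounds shown, and "the series" means these compounds.

In a functional assay on A549 cells (Homo sapiens) for antiproliferative activity, read by MTT assay, with a stated time of 48 h (a higher number here means a weaker inhibitor, a lower number a stronger inhibitor), compound 1 (`Cc1ccc(-c2cc(NC(=O)/C=C/c3ccc(Cl)cc3)n[nH]2)cc1`) gives 1490 nM and compound 2 (`COc1ccc(/C=C/C(=O)Nc2cc(-c3ccc(Br)cc3)[nH]n2)cc1`) gives 820 nM. Going by the values given here, compound 1 therefore stands within the scatter of the only other measured compound. Compound 3 (`O=C(/C=C/c1ccc(Cl)cc1)Nc1cc(-c2ccccc2)[nH]n1`) has not yet been measured in this assay. It differs from compound 1 by hydrogen in place of methyl on an aromatic carbon, para to a large group: hydrogen in place of methyl on an aromatic carbon. The same difference reads 4-methylphenyl to phenyl. Among the compounds with values here, no measured pair differs in one place, so the series gives no direct precedent for this change, and the estimate carries a wide range. No step beyond the scatter is expected in this assay, and no direction is favoured. The expected change is a 1.0-fold higher number from compound 1 to compound 3 (0.00 log units; within the scatter). Compound 3 is estimated at 1500 nM, with an expected range of 600 nM to 3600 nM.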

Compound 3, half-maximal inhibitory concentration: 1390 nM
For compound 3 the middle estimate is 1.1-fold (0.03 log units) above the measured one, within the range that was stated.
By their numbers in this assay, from the lowest: compounds 2, 3 and 1 (each within the scatter of the next).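

In this assay, going by these compounds alone, hydrogen in place of methyl on an aromatic carbon, para to a large group, gives a 1.1-fold lower number from compound 1 to compound 3 (0.03 log units; within the scatter) and is the first direct reading of a single change. At this position, the 4-methylphenyl to phenyl change therefore leaves the number within the scatter, so this methyl is not required for the antiproliferative activity seen here. No measurement accompanies this result that could bear on it.

Going by these compounds, this single pair covers only methyl and hydrogen, so it remains open whether an amine, a carboxylic acid or a longer alkyl chain at the same position would also leave the number within the scatter. Compound 2 differs from the other compounds in more than one place, so the separate contributions of its changes cannot be read.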